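The source may report more compounds than this note shows. Statements on the series, on what has been measured and on what is new or still open speak of the compounds shown alone.

Three compounds sharing one core were tested in a functional assay on the whole organism (strain albino) with Mus musculus as the target, with a stated time of 30 min; on this read-out lower numbers stand for an effect already at smaller amounts and higher numbers for an effect only at larger amounts of compound. Compound 1 `Cc1ccc(C(=O)N/N=C/c2c(C)nn(-c3ccccc3)c2Cl)cc1` carries a methyl on an aromatic carbon, and in this assay compound 1 gives 300 mg/kg. Compound 2 `COc1ccc(C(=O)N/N=C/c2c(C)nn(-c3ccccc3)c2Cl)cc1` has a methoxy in place of that methyl; in this assay compound 2 gives 300 mg/kg, and no change at the digits printed from compound 1 to compound 2 (within the scatter). Compound 3 `Cc1nn(-c2ccccc2)c(Cl)c1/C=N/NC(=O)c1ccccc1` has hydrogen at that carbon, and in this assay compound 3 gives 100 mg/kg, the lowest number of the three: a 3.0-fold lower number from compound 1 to compound 3 (0.48 log units; beyond the scatter) and a 3.0-fold lower number from compound 2 to compound 3 (0.48 log units; beyond the scatter). Both steps lie beyond the scatter and point the same way, so the plain phenyl on the carbonyl carbon acts at smaller amounts than either decorated version.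

Compound 4 `Cc1nn(-c2ccccc2)c(Cl)c1/C=N/NC(=O)COc1ccccc1` alters that same region in a different manner: phenoxymethyl in place of phenyl on a carbonyl carbon. Among the compounds with values here, no measured step covers this kind of change, so the two steps leading to compound 3 bear on it only loosely; they show that this part of the molecule responds to alteration by amounts beyond the scatter, and that every alteration tried so far raised the number relative to compound 3. A modest rise is therefore expected, a 1.5-fold higher number from compound 3 to compound 4 (0.18 log units; within the scatter), though the direction is uncertain. Compound 4 is estimated at 150 mg/kg, with a likely range from 60 mg/kg to 400 mg/kg.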

Compound 4, dose for half-maximal effect: 100 mg/kg
The estimate for compound 4 lay 1.5-fold (0.18 log units) above the measured number, and the stated range covers the measured number.
By their numbers in this assay, from the lowest: compounds 3 and 4 (each within the scatter of the next); then compounds 1 and 2 (each within the scatter of the next).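

In this assay, phenoxymethyl in place of phenyl on a carbonyl carbon gives no change at the digits printed from compound 3 to compound 4 (within the scatter), so in this pair the aromatic ring need not be bonded straight to the carbonyl carbon for the number to hold. Within the data shown here, this is the first alteration at this position that does not raise the number relative to compound 3, and the new group also reads well against the decorated phenyl groups, with a 3.0-fold lower number from compound 2 to compound 4 (0.48 log units; beyond the scatter) and a 3.0-fold lower number from compound 1 to compound 4 (0.48 log units; beyond the scatter), which match the gaps already seen for compound 3. Nothing available here explains why these groups give the numbers they do.

As far as these compounds go, it remains open whether a methyl or a methoxy on the ring of the phenoxymethyl group would raise the number, as each does on the phenyl ring of compound 3. Also open, from the compounds shown here alone, is how a longer chain, or a chain ending in an amine or a carboxylic acid, would fare on this carbonyl carbon, and whether any group there could bring the number below the value shared by compound 3 and compound 4.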